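The compounds below may be only part of what the source reports. "The series", "measured", "known", "first", "only" and "open" are said of these compounds alone.

Three compounds were measured in a functional assay on Huh-7 cells (Homo sapiens) for inhibition, read by sulforhodamine B assay, with a stated time of 72 h; on this read-out lower numbers stand for stronger inhibition and higher numbers for weaker inhibition:

compound 1, `COc1ccc(C(=O)/C=C/c2cn(-c3ccccc3)nc2-c2ccsc2)c(OC)c1OC`, 4200 nM
compound 2, `COc1ccc(C(=O)/C=C/c2cn(-c3ccccc3)nc2-c2ccsc2)cc1OC`, 2900 nM
compound 3, `COc1ccc(C(=O)/C=C/c2cn(-c3ccccc3)nc2-c2ccncc2)c(OC)c1OC`, 3700 nM

Compound 3 differs from compound 1 by pyridin-4-yl in place of thiophen-3-yl on an aromatic carbon, and the two values lie within the usual scatter of each other. Compound 2 differs from compound 1 by hydrogen in place of methoxy on an aromatic carbon, a step of a 1.4-fold lower number from compound 1 to compound 2 (0.16 log units; within the scatter), also within the scatter. Compound 4, `COc1ccc(C(=O)/C=C/c2cn(-c3ccccc3)nc2-c2ccncc2)cc1OC`, is not yet measured; it differs from compound 3 by hydrogen in place of methoxy on an aromatic carbon, the same change as from compound 1 to compound 2, at a place described in the same words. Among the compounds with values here, for compound 4 a step of a 1.4-fold lower number from compound 3 to compound 4 (0.14 log units; within the scatter) is expected in this assay, resting on the single earlier instance of this change, a 1.4-fold lower number from compound 1 to compound 2 (0.16 log units; within the scatter). Compound 4 is therefore estimated to give 2700 nM, with a range from 1300 nM to 5500 nM.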

Compound 4, half-maximal inhibitory concentration: 2000 nM
Compound 4: middle estimate off by 1.4-fold (0.13 log units), on the high side, within the range that was stated.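

In this assay, hydrogen in place of methoxy gives a 1.9-fold lower number from compound 3 to compound 4 (0.27 log units; within the scatter), which matches the earlier case of this change: the same change on two cores in this assay, a 1.4-fold lower number (0.16 log units; within the scatter) from compound 1 to compound 2 and a 1.9-fold lower number (0.27 log units; within the scatter) from compound 3 to compound 4, 1.3-fold (0.11 log units) apart, within the scatter of two such steps. Pyridin-4-yl in place of thiophen-3-yl gives a 1.5-fold lower number from compound 2 to compound 4 (0.16 log units; within the scatter), and this also matches its earlier case: the same change on two cores in this assay, a 1.1-fold lower number (0.06 log units; within the scatter) from compound 1 to compound 3 and a 1.5-fold lower number (0.16 log units; within the scatter) from compound 2 to compound 4, 1.3-fold (0.11 log units) apart, within the scatter of two such steps. Both changes therefore carry from one core to the other without a difference that can be told apart, but every step lies within the scatter, so this does not show that either change truly moves the number, and two cores are a narrow basis for any rule.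

Still open, as far as these compounds go, is whether an amine or a carboxylic acid in place of a methoxy group would give a step beyond the scatter, and whether such a step would carry between these cores.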